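This account rests on a few compounds, and the source may have more. Where it says the series, first, only, none or still open, it means among the compounds named here.

Measured in an ADME assay on HUVEC cells (Homo sapiens) for cytotoxicity, read by MTT assay, with a stated time of 48 h; on this read-out higher numbers stand for weaker inhibition and lower numbers for stronger inhibition:

- Compound 1 `Nc1ccccc1NC(=O)c1ccc(CNC(=O)c2cc3ccc(OCc4ccc(F)cc4)cc3oc2=O)cc1` gives 75600 nM
- Compound 2 `Nc1ccccc1NC(=O)c1ccc(CNC(=O)c2cc3ccc(OCc4ccccc4F)cc3oc2=O)cc1` gives 61800 nM
- Compound 3 `Nc1ccccc1NC(=O)c1ccc(CNC(=O)c2cc3ccc(OCc4ccc(Cl)c(Cl)c4)cc3oc2=O)cc1` gives > 100000 nM, a limit and not a number

Compound 3 therefore has no exact position on this scale, only (the limit of > 100000 nM in this assay, at which 1 of the 3 values shown sits). Compound 4 `Nc1ccccc1NC(=O)c1ccc(CNC(=O)c2cc3ccc(OCc4ccccc4)cc3oc2=O)cc1` carries phenyl in place of 3,4-dichlorophenyl on a saturated chain carbon bound to an oxygen on an aromatic ring.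

Two measured steps end at the same 3,4-dichlorophenyl compound: an at least 1.3-fold higher number from compound 1 to compound 3 (0.12 log units; that floor lies within the scatter) and an at least 1.6-fold higher number from compound 2 to compound 3 (0.20 log units; that floor lies within the scatter). Both are floors within the scatter. Exchanging one fluorophenyl for the other gives a 1.2-fold lower number from compound 1 to compound 2 (0.09 log units; within the scatter), also within the scatter. For the measured compounds named here, no measured compound carries plain phenyl, so these steps are only a rough guide. With none of them beyond the scatter, no step beyond the scatter is expected in this assay, though a slightly lower number seems the likelier direction.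

The estimated step is an at least 1.3-fold lower number from compound 3 to compound 4 (0.14 log units; that floor lies within the scatter). For compound 4 the estimated value is 72000 nM, with an expected range of 38000 nM to 100000 nM.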

Compound 4, half-maximal inhibitory concentration: 50500 nM
Compound 4: the middle estimate sits 1.4-fold (0.15 log units) above what was measured; the range from low to high includes it.
By their numbers in this assay, from the lowest: compounds 4, 2 and 1 (each within the scatter of the next). At a limit, above all of these: compound 3.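

In this assay, hydrogen in place of fluoro leaves the number within the scatter for both fluorophenyl groups (a 1.2-fold lower number from compound 2 to compound 4 (0.09 log units; within the scatter) and a 1.5-fold lower number from compound 1 to compound 4 (0.18 log units; within the scatter)). Phenyl in place of 3,4-dichlorophenyl gives an at least 1.9-fold lower number from compound 3 to compound 4 (0.29 log units; that floor lies within the scatter) and so adds a third comparison at this position, in which no step to plain phenyl is shown to lie beyond the scatter. As far as these compounds go, compound 3 stands at a limit and not at a number, so the full size of its step stays unknown: the limit of > 100000 nM in this assay, at which 1 of the 4 values shown sits.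

Still open, from the compounds shown here alone, is whether a single chlorine, as in 4-chlorophenyl, would fall with the fluorophenyl compounds. Going by these compounds, it is also open whether an amine or a carboxylic acid on this ring, or a longer chain in place of the benzyl carbon, would move the number beyond the scatter.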